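Swapping the methoxyphenyl for a difluorophenyl ketone

The source may hold more compounds than are shown below. What is called first, only, known or untested is meant among the compounds shown, and "the series" means these compounds.

Compound 2 `COc1ccc(C(=O)/C=C/c2cc(-c3cc(OC)c(OC)c(OC)c3)n[nH]2)cc1` is one of two measured analogues that share a core, the other being compound 1 `COc1ccc(C(=O)/C=C/c2cc(-c3cc(OC)c(OC)c(OC)c3)n[nH]2)cc1OC`. For the measured compounds named here, in a functional assay on MDA-MB-468 cells (Homo sapiens) for inhibition, read by sulforhodamine B assay, with a stated time of 48 h (on this read-out lower numbers stand for stronger inhibition of growth and higher numbers for weaker inhibition of growth), compound 1 gives 750 nM, and in this assay compound 2 gives 1290 nM, the higher of the two numbers; the only measured step, a 1.7-fold higher number from compound 1 to compound 2 (0.24 log units; within the scatter), lies within the scatter. Compound 3 `COc1cc(-c2cc(/C=C/C(=O)c3ccc(F)c(F)c3)[nH]n2)cc(OC)c1OC` has not been measured. It differs from compound 2 by 3,4-difluorophenyl in place of 4-methoxyphenyl on a carbonyl carbon. Going by the values given here, no measured step changes this ring in the same way; the step from compound 1 to compound 2, which altered the same ring by removing a methoxy, was small. On that basis only a modest shift is expected, if any, with a 1.4-fold higher number from compound 2 to compound 3 (0.14 log units; within the scatter). Compound 3 is therefore estimated at 1800 nM in this assay, with a likely range from 600 nM to 5400 nM.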

Compound 3, concentration for 50% growth inhibition: 2220 nM
The estimate for compound 3 lay 1.2-fold (0.09 log units) below the measured number; measured number inside the range.
By their numbers in this assay, from the lowest: compounds 1, 2 and 3 (each within the scatter of the next, the first and the last beyond it).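

In this assay, putting 3,4-difluorophenyl in place of 4-methoxyphenyl on the carbonyl carbon gives a 1.7-fold higher number from compound 2 to compound 3 (0.24 log units; within the scatter), so this exchange alone cannot be told apart from repeat measurement. Against the 3,4-dimethoxyphenyl of compound 1, the same 3,4-difluorophenyl gives a 3.0-fold higher number from compound 1 to compound 3 (0.47 log units; beyond the scatter), the first step at this position to pass beyond the scatter, which shows that the group on the carbonyl carbon can affect growth inhibition, though only modestly. Nothing available here bears on why the numbers differ. The compounds shown leave open whether an amine or a carboxylic acid on this ring would shift the number further, and in which direction. They also leave open whether a single fluorine would behave like the 3,4-difluorophenyl group.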